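Allyl to furanylmethyl on the ring nitrogen

A few compounds are considered here, and "the series" means these few. Any claim that something is new, unique, unknown or untested is made for them only; others in the source may bear on it.

Among the compounds with values here, compound 3 `C=CCn1c(=O)c(-c2cccc([N+](=O)[O-])c2)nc2ccccc21` is the one member of this small set that gives an actual number in an assay on cells for activation of Cystic fibrosis transmembrane conductance regulator (Homo sapiens), read by fluorescence, with a stated time of 10 min (on this read-out higher numbers stand for an effect only at larger amounts of compound and lower numbers for an effect already at smaller amounts), where compound 3 reaches 55 nM. For compound 1 `O=c1[nH]c2ccccc2nc1-c1cccc([N+](=O)[O-])c1` the assay reports only a limit, > 10000 nM. For compound 2 `Cn1c(=O)c(-c2cccc([N+](=O)[O-])c2)nc2ccccc21` the result is again a limit, > 10000 nM. Since two of the three results sit at the limit of > 10000 nM in this assay, at which 2 of the 3 values shown sit, the steps leading to compound 3 can only be read as lower bounds: an at least 180-fold lower number from compound 1 to compound 3 (2.25 log units; beyond the scatter) and an at least 180-fold lower number from compound 2 to compound 3 (2.25 log units; beyond the scatter). The step from hydrogen to methyl on that nitrogen, a step that the two limits leave unreadable from compound 1 to compound 2, cannot be sized at all.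

Compound 4 `O=c1c(-c2cccc([N+](=O)[O-])c2)nc2ccccc2n1Cc1ccco1` keeps the shared core and alters only the group on the ring nitrogen: furan-2-yl in place of vinyl on a saturated chain carbon bound to an aromatic nitrogen. Within the data shown here, none of the measured steps exchanges one such substituent for another; the two readable steps only show that an allyl group on that nitrogen, as in compound 3, brings the number far down, whereas a methyl group there, as in compound 2, leaves it at the limit. Compound 4 keeps a group on this nitrogen and enlarges it, so the expectation rests on compound 3 alone. The expected step of a 1.1-fold higher number from compound 3 to compound 4 (0.04 log units; within the scatter) is accordingly small, within the scatter, with no firm direction. Compound 4 is estimated at 60 nM, with a range from 15 nM to 400 nM.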

Compound 4, half-maximal effective concentration: 20 nM
The estimate for compound 4 lay 3.0-fold (0.48 log units) above the measured number, and the stated range covers the measured number.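

The position turns out to accept more than one kind of group. In this assay, furan-2-yl in place of vinyl gives a 2.8-fold lower number from compound 3 to compound 4 (0.44 log units; beyond the scatter), a modest step that lies beyond the scatter, so a five-membered aromatic ring at this place keeps the number low and takes it somewhat lower still. Compared with the compounds carrying a smaller group on the ring nitrogen, the change is much larger, at an at least 500-fold lower number from compound 2 to compound 4 (2.69 log units; beyond the scatter) and an at least 500-fold lower number from compound 1 to compound 4 (2.69 log units; beyond the scatter), so among the compounds shown, allyl and (furan-2-yl)methyl give real numbers while methyl and hydrogen do not. These two large steps are lower bounds and not exact sizes, because their starting values are limits: the limit of > 10000 nM in this assay, at which 2 of the 4 values shown sit.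

The compounds shown leave open whether the gain belongs to the furan ring, to its oxygen, or to any group larger than methyl, and a benzyl group or a plain propyl chain on this nitrogen would help to separate these. They also leave open whether a group carrying an amine or a carboxylic acid would be accepted here.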